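A few compounds are considered here, and "the series" means these few. Any claim that something is new, unique, unknown or untested is made for them only; others in the source may bear on it.

In a functional assay on P388 cells (Mus musculus) for antiproliferative activity, read by colorimetric assay and MTT assay (a lower number here means a stronger inhibitor, a higher number a weaker inhibitor), compound 1 (`O=S(=O)(Nc1cccc2cc(O)[nH]c12)c1ccc(Cl)cc1`) gives 2.2 ug/mL, compound 2 (`N#Cc1ccc(S(=O)(=O)Nc2ccc(Cl)c3c(Cl)c[nH]c23)cc1`) gives 0.59 ug/mL and compound 3 (`Nc1ccc(S(=O)(=O)Nc2ccc(Cl)c3c(Cl)c[nH]c23)cc1`) gives 0.49 ug/mL. Compound 3 stands level with compound 2 within the scatter, and well under compound 1. Compound 4 (`COc1ccc(NS(=O)(=O)c2ccc(N)cc2)c2[nH]cc(Cl)c12`) has methoxy in place of chloro on an aromatic carbon, para to a large group: methoxy in place of chloro on an aromatic carbon. Among the compounds with values here, the only measured single change, a 1.2-fold lower number from compound 2 to compound 3 (0.08 log units; within the scatter), swapped cyano for amino elsewhere in the molecule and stayed within the scatter. Within the data shown here, no measured step touches this chloro, so that evidence is weak, and no step beyond the scatter is expected in this assay. That expectation is an estimated 1.2-fold higher number from compound 3 to compound 4 (0.09 log units; within the scatter). The expected value for compound 4 is 0.6 ug/mL, with an estimated range of 0.2 ug/mL to 1.8 ug/mL.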

Compound 4, half-maximal inhibitory concentration: 5.5 ug/mL
For compound 4 the middle estimate is 9.2-fold (0.96 log units) below the measured one, outside the stated range (above it).
By their numbers in this assay, from the lowest: compounds 3 and 2 (each within the scatter of the next); then compound 1; then compound 4.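

In this assay, the change at this aromatic carbon, para to a large group, gives an 11-fold higher number from compound 3 to compound 4 (1.05 log units; beyond the scatter), so methoxy in place of chloro is not tolerated as the earlier cyano-to-amino change was. Within the data shown here, this position therefore responds strongly to substitution, which the earlier compounds could not show. No measurement here explains the loss.

As far as these compounds go, it remains open whether the loss follows from removing chloro or from introducing methoxy. Fluoro, methyl or hydrogen at this carbon would help separate the two.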